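The compounds below may be only part of what the source reports. "The series", "measured", "known", "first", "only" and "open" are said of these compounds alone.

Working notes on the series, read in a functional assay on HT-1080 cells (Homo sapiens) for antiproliferative activity, read by MTT assay, with a stated time of 72 h; on this read-out higher numbers stand for weaker inhibition and lower numbers for stronger inhibition. Compound 1 `CCOC(=O)c1cc(-c2ccc(OC)c(O)c2)c(-c2cc(OC)c(OC)c(OC)c2)s1` gives 82600 nM, and compound 2 `COc1ccc(-c2cc(C(=O)O)sc2-c2cc(OC)c(OC)c(OC)c2)cc1[N+](=O)[O-]` gives 38100 nM. Compound 3 `COc1ccc(-c2cc(C(=O)O)sc2-c2cc(OC)c(OC)c(OC)c2)cc1OCc1ccccc1` gives only a limit, > 100000 nM, and so stands at the limit of > 100000 nM in this assay, at which 1 of the 3 values shown sits.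

Compound 4 `COc1ccc(-c2cc(C(=O)O)sc2-c2cc(OC)c(OC)c(OC)c2)cc1O` differs from compound 3 in one place: hydrogen in place of benzyl on an oxygen on an aromatic ring. This is hydrogen in place of benzyl on an oxygen on an aromatic ring, or benzyloxy to hydroxy.

For the measured compounds named here, one measured step touches the same group: an at least 2.6-fold higher number from compound 2 to compound 3 (0.41 log units; beyond the scatter), with benzyloxy in place of nitro. That step is beyond the scatter and open-ended, so the change to compound 4 is expected to lower the number in this assay, towards stronger inhibition. Compound 1 also carries a hydroxy group and gives 82600 nM, so only a modest step is expected, not a large one.

The estimated move is an at least 2.0-fold lower number from compound 3 to compound 4 (0.30 log units; that floor lies within the scatter). For compound 4 the expected value is 50000 nM, with an estimated range of 15000 nM to 100000 nM.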

Compound 4, half-maximal inhibitory concentration: 11400 nM
For compound 4 the middle estimate is 4.4-fold (0.64 log units) above the measured one; the whole stated range lies above it.
By their numbers in this assay, from the lowest: compound 4; then compound 2; then compound 1. At a limit, above all of these: compound 3.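

In this assay, hydrogen in place of benzyl on an oxygen on an aromatic ring gives an at least 8.7-fold lower number from compound 3 to compound 4 (0.94 log units; beyond the scatter), so at this position the free hydroxy carries the lower number and the benzyloxy the higher. Compound 3 stands only at a limit of the assay: the limit of > 100000 nM in this assay, at which 1 of the 4 values shown sits. Hydroxy also improves on nitro at the same aromatic carbon, with a 3.3-fold lower number from compound 2 to compound 4 (0.52 log units; beyond the scatter), but the hydroxy alone does not set the number, since hydrogen in place of ethyl on an oxygen next to a carbonyl group gives a 7.2-fold lower number from compound 1 to compound 4 (0.86 log units; beyond the scatter).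

The compounds shown leave open whether an amine or a fluorine at this position would lower the number further than hydroxy. They also leave open whether an amide could stand in for the carboxylic acid without raising it.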